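Amide chain extension: propyl to butyl

The source may hold more compounds than are shown below. What is called first, only, known or untested is meant among the compounds shown, and "the series" means these compounds.

Measured in a functional assay on NCI-H1975 cells (Homo sapiens) for antiproliferative activity, read by CCK-8 assay, with a stated time of 72 h; a lower number here means a stronger inhibitor of growth, a higher number a weaker inhibitor of growth:
- compound 1 `CCC1C(=O)N(C)c2cnc(-n3ccc4cc(C(=O)NC(C)C)ccc43)nc2N1c1ccn(C)n1`: 12200 nM
- compound 2 `CCC1C(=O)N(C)c2cnc(-n3ccc4cc(F)ccc43)nc2N1c1ccn(C)n1`: 28600 nM
- compound 3 `CCCNC(=O)c1ccc2c(ccn2-c2ncc3c(n2)N(c2ccn(C)n2)C(CC)C(=O)N3C)c1`: 11000 nM

Compound 3, at 11000 nM, cannot be separated from compound 1 within the scatter. The gap to the fluoro analogue is modest but beyond the scatter: a 2.6-fold lower number from compound 2 to compound 3 (0.41 log units; beyond the scatter).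

Next is compound 4 `CCCCNC(=O)c1ccc2c(ccn2-c2ncc3c(n2)N(c2ccn(C)n2)C(CC)C(=O)N3C)c1`, where propyl becomes butyl on the amide. The change is methyl in place of hydrogen on a saturated chain carbon, three bonds along the chain from an amide-type nitrogen.

The closest evidence is the swap of isopropyl for propyl on the amide nitrogen, a 1.1-fold lower number from compound 1 to compound 3 (0.04 log units; within the scatter), which stays within the scatter. The replacement of the whole carbamoyl group by fluoro, a 2.3-fold higher number from compound 1 to compound 2 (0.37 log units; beyond the scatter), is modest, and it is a much larger structural change than the one here. No butyl amide has been measured, so this rests on a single close comparison. In this assay, no step beyond the scatter is expected, and the direction is left open. The expected step is a 1.1-fold lower number from compound 3 to compound 4 (0.04 log units; within the scatter). For compound 4 the estimated value is 10000 nM, with an expected range of 5500 nM to 20000 nM.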

Compound 4, concentration for 50% growth inhibition: 12000 nM
Beside the measured number, compound 4's estimate is 1.2-fold (0.08 log units) below it; low and high end bracket the measured number.
By their numbers in this assay, from the lowest: compounds 3, 4 and 1 (each within the scatter of the next); then compound 2.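

In this assay, within the data shown here, the added methyl on a saturated chain carbon, three bonds along the chain from an amide-type nitrogen, gives no step that can be told from the scatter (a 1.1-fold higher number from compound 3 to compound 4 (0.04 log units; within the scatter)), and butyl in place of isopropyl on the amide nitrogen gives none either (a 1.0-fold lower number from compound 1 to compound 4 (0.01 log units; within the scatter)), so the isopropyl, propyl and butyl amides now stand as one group of three that this read-out cannot order. Among these compounds, the butylcarbamoyl group keeps a modest gap to fluoro on the aromatic carbon (a 2.4-fold lower number from compound 2 to compound 4 (0.38 log units; beyond the scatter)), so in these compounds the only steps beyond the scatter still come from replacing the whole carbamoyl group, not from changing its chain. No supporting measurement bears on this result.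

As far as these compounds go, whether a much longer chain such as octyl, or a chain ending in an amine or a carboxylic acid, would move the number stays open. The compounds shown also leave open what a tertiary amide would do, with a methyl in place of the amide hydrogen.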